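From Amino to Hydrogen in a Lipid Phosphate Agonist

The source may hold more compounds than are shown below. What is called first, only, known or untested is meant among the compounds shown, and "the series" means these compounds.

Compound 2 `CCCCCCCC/C=C\CCCCCCCC(=O)N[C@H](CN)COP(=O)(O)O` carries an amino group, and in an assay on HEK-293T cells for agonist activity at lysophosphatidic acid receptor 3 (Homo sapiens), with a stated time of 30 min (a higher number here means that more compound is needed for the effect, a lower number that less compound is needed), compound 2 gives 684 nM. Among the compounds with values here, that is the highest of the two numbers measured so far; its nearest neighbour is compound 1 `CCCCCCCC/C=C\CCCCCCCC(=O)N[C@H](CO)COP(=O)(O)O`, which in this assay gives 322 nM. Within the data shown here, the one measured step, a 2.1-fold higher number from compound 1 to compound 2 (0.33 log units; beyond the scatter), shows that exchanging hydroxy for amino at this place moved the number upward only a little. Compound 3 `CCCCCCCC/C=C\CCCCCCCC(=O)N[C@H](C)COP(=O)(O)O` goes one step further: hydrogen in place of amino on a saturated chain carbon, two bonds along the chain from an amide-type nitrogen. Among the measured compounds shown here, no measured pair shows the removal of such a group altogether, so the only guide is that one modest step, and it leaves the direction open. Compound 3 is expected to need somewhat more material than its neighbours, with wide uncertainty, an expected step of a 1.4-fold higher number from compound 2 to compound 3 (0.14 log units; within the scatter). The estimate for compound 3 in this assay is 950 nM, with a range from 250 nM to 3600 nM.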

Compound 3, half-maximal effective concentration: 113 nM
Beside the measured number, compound 3's estimate is 8.4-fold (0.92 log units) above it; measured number below the stated range.
By their numbers in this assay, from the lowest: compound 3; then compound 1; then compound 2.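

At this place, on a saturated chain carbon, two bonds along the chain from an amide-type nitrogen, losing the group altogether lowers the number in this assay: hydrogen in place of amino gives a 6.1-fold lower number from compound 2 to compound 3 (0.78 log units; beyond the scatter), and hydrogen in place of hydroxy gives a 2.8-fold lower number from compound 1 to compound 3 (0.45 log units; beyond the scatter). The earlier step only compared amino with hydroxy, whereas these steps show that neither group is needed for the effect, since compound 3 carries neither and needs the least compound of the three, beyond the scatter against both others. No measurement shown explains why removing either group lowers the number.

What the compounds shown leave open is how a fluorine atom, a methoxy group or a longer chain such as ethyl would behave at this place. Also open, going by these compounds, is whether a carboxylic acid here would follow the same order.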